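A Pyrazole in Place of a Pyridine

This account rests on a few compounds, and the source may have more. Where it says the series, first, only, none or still open, it means among the compounds named here.

In a functional assay on A-375 cells (Homo sapiens) for activation, with a stated time of 3 days (on this read-out higher numbers stand for an effect only at larger amounts of compound and lower numbers for an effect already at smaller amounts), compound 1 `O=C(Nc1ccc(-c2cscn2)cc1)C1CCCN(C(=O)c2ccc(F)c(F)c2)C1` is recorded at > 20000 nM, which is a limit of the assay and not a number. Among the measured compounds shown here, compound 2 `O=C(Nc1ccc(-c2ccncc2)cc1)C1CCCN(Cc2ccc(F)c(F)c2)C1` gives 1180 nM, the only true number so far, so it is the one measured reference point. The two compounds differ in more than one place, so their values do not show what any single change does.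

Compound 3 `O=C(Nc1ccc(-c2ccn[nH]2)cc1)C1CCCN(Cc2ccc(F)c(F)c2)C1` keeps the rest of compound 2 and changes one group, with 1H-pyrazol-5-yl in place of pyridin-4-yl on an aromatic carbon, para to a large group (1H-pyrazol-5-yl in place of pyridin-4-yl on an aromatic carbon). Both groups are small aromatic rings, but they differ in ring size and in what they can offer for hydrogen bonding.

For the measured compounds named here, no measured pair shows what this swap does in this assay, so the expectation starts from compound 2 at 1180 nM and stays wide. A moderate move towards a higher number is expected, with an estimated step of a 1.7-fold higher number from compound 2 to compound 3 (0.23 log units; within the scatter). For compound 3 the estimated value is 2000 nM, with an expected range of 400 nM to 10000 nM.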

Compound 3, half-maximal effective concentration: 580 nM
Beside the measured number, compound 3's estimate is 3.4-fold (0.54 log units) above it; measured number inside the range.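

In this assay, among the compounds shown here, putting 1H-pyrazol-5-yl in place of pyridin-4-yl gives a 2.0-fold lower number from compound 2 to compound 3 (0.31 log units; beyond the scatter), which is the first single change that can be read. The step is modest, but it shows that this position, on an aromatic carbon para to a large group, does not depend on a six-membered aromatic ring: a five-membered aromatic ring with 2 hetero atoms works at least as well here, and the number moves in the favourable direction. The new ring differs from the old one in ring size, in its hetero atoms and in carrying a hydrogen-bond donor, and nothing measured here tells which of these differences accounts for the step.

A pyrazole with a methyl group on its ring nitrogen, or a plain phenyl ring, at this same position would help to separate the effect of the donor from that of the ring itself. As far as these compounds go, it also remains open whether the same swap gives a similar step when other parts of the shared core are changed, such as the difluorobenzyl group.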